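A Trifluoromethylphenyl Replacement on the Piperazine of Compound 1

The source may report more compounds than this note shows. Statements on the series, on what has been measured and on what is new or still open speak of the compounds shown alone.

Going by the values given here, compound 1 `Cc1nc(-c2ccccc2)c(C(=O)N2CCN(c3cccc(C)c3C)CC2)o1` is the only member of this set with a measured number: in a functional assay on HL-60 cells (Homo sapiens) for inhibition, read by MTT assay, with a stated time of 72 h (on this read-out lower numbers stand for stronger inhibition and higher numbers for weaker inhibition), compound 1 gives 35 nM. Compound 2 `Cc1nc(-c2ccc(F)cc2)c(C(=O)N2CCN(c3ccc(Cl)cc3)CC2)o1` gives "not active" (no number reported) in this assay. Compound 3 `O=C(c1oc(C(F)(F)F)nc1-c1cccc(Cl)c1)N1CCN(c2cccc(Cl)c2)CC1` likewise gives "not active" (no number reported) in this assay. Compound 4 `Cc1nc(-c2ccccc2)c(C(=O)N2CCN(c3ccc(C(F)(F)F)cc3)CC2)o1` is not yet measured. It differs from compound 1 in one place: 4-(trifluoromethyl)phenyl in place of 2,3-dimethylphenyl on an amine nitrogen in a ring. Among the compounds with values here, no step between measured compounds is available, and compounds 2 and 3 differ from compound 1 in more than one place, so they cannot isolate this change. The expected step of an 11-fold higher number from compound 1 to compound 4 (1.06 log units; beyond the scatter) is a loss beyond the usual scatter, with wide uncertainty. Compound 4 is therefore estimated at 400 nM, within a range from 80 nM to 3000 nM.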

Compound 4, half-maximal inhibitory concentration: > 1000 nM
Compound 4: no number, only a limit; the forecaster's own chance of this, stated with the estimate: 40%; at least 2.5-fold (0.39 log units) between middle value and limit.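

Going by these compounds alone, this gives the first single-place comparison in the set: in this assay, 4-(trifluoromethyl)phenyl in place of 2,3-dimethylphenyl on an amine nitrogen in a ring gives an at least 28-fold higher number from compound 1 to compound 4 (1.45 log units; beyond the scatter). The aryl group at this position therefore weighs heavily on the read-out, with the rest of compound 1 unchanged. For compound 4 the reading is a limit and not a number, and the full size of the loss stays unread: the limit of > 1000 nM in this assay, at which 1 of the 4 values shown sits.

The compounds shown leave open whether the loss follows from losing the two methyl groups or from gaining the trifluoromethyl group. A plain phenyl group on that nitrogen would separate the two.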